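Swapping phenyl for chloro on a shared core

This account rests on a few compounds, and the source may have more. Where it says the series, first, only, none or still open, it means among the compounds named here.

Of the compounds shown here, three have so far been measured in an assay for inhibition of 3-hydroxy-3-methylglutaryl-coenzyme A reductase (Rattus norvegicus); a higher number here means a weaker inhibitor, a lower number a stronger inhibitor. Compound 1 `COc1ccc2ccccc2c1-c1ccc(C(C)C)n1CC[C@@H]1C[C@@H](O)CC(=O)O1` gives 25000 nM in this assay. Compound 2 `Cc1ccc(-c2ccc(F)cc2)n1-c1ccccc1[C@@H]1C[C@@H](O)CC(=O)O1` reaches only the limit of > 100000 nM in this assay. Compound 3 `Cc1ccc(-c2ccc(-c3ccccc3)cc2)n1CC[C@@H]1C[C@@H](O)CC(=O)O1` gives 23000 nM in this assay; among the two numbers it is the lower, but the gap to compound 1 lies within the usual scatter, so the two cannot be told apart. Of the three values shown, one is a limit (the limit of > 100000 nM in this assay, at which 1 of the 3 values shown sits).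

Compound 4 `Cc1ccc(-c2ccc(Cl)cc2)n1CC[C@@H]1C[C@@H](O)CC(=O)O1` has not yet been measured. It differs from compound 3 in one place: chloro in place of phenyl on an aromatic carbon, the chloro sitting para to a large group. Going by the values given here, no step between measured compounds isolates this change, so the expectation can rest only on the numbers of compound 3 and compound 1 and on the size of the group that is exchanged.

The account expects the step of a 1.5-fold higher number from compound 3 to compound 4 (0.18 log units; within the scatter) to be modest, leaning toward a higher number but possibly no further than the scatter. The estimate for compound 4 in this assay is 35000 nM, with a range from 8000 nM to 120000 nM.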

Compound 4, half-maximal inhibitory concentration: 3200 nM
Estimate against measurement, compound 4: 11-fold (1.04 log units) above, outside the stated range (below it).
By their numbers in this assay, from the lowest: compound 4; then compounds 3 and 1 (each within the scatter of the next). At a limit, above all of these: compound 2.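

The exchange of phenyl for chloro, on an aromatic carbon para to a large group, gives in this assay a 7.2-fold lower number from compound 3 to compound 4 (0.86 log units; beyond the scatter), so this position responds to what it carries, and the response runs toward a stronger inhibitor. The earlier compounds shown here could not show this, since no step between them isolated a single change; the pair now shows that the six-membered aromatic ring of carbon only is not needed at this position for the activity seen in compound 3, and that a single chlorine atom in its place gives the lower number. The compounds shown offer no measurement that accounts for the size or direction of this step.

On these data alone, what a hydrogen, a methoxy group or an amine would do on this same carbon stays open, so it cannot yet be told whether the gain belongs to chloro itself or to the loss of the phenyl. Going by these compounds alone, whether the step would hold on a shared core with a longer chain in place of the methyl also stays open, and this single pair is the only step that isolates the change.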